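The source may report more compounds than this note shows. Statements on the series, on what has been measured and on what is new or still open speak of the compounds shown alone.

In an in vitro ADME assay on microsomes from liver (Homo sapiens) for metabolic stability (a lower number here means slower removal, a higher number faster removal of the compound), two compounds sharing one core have been measured. Compound 1 (`C[C@@H]1CN(Cc2ccc(-c3ccccc3CN(C)C(=O)COc3ccccc3)cc2)C[C@H](C)N1`) gives 4.9 mL.min-1.g-1, and compound 2 (`C[C@@H]1CN(Cc2ccc(-c3ccccc3CN(C)C(=O)CS(=O)(=O)c3ccccc3)cc2)C[C@H](C)N1`) gives 6.8 mL.min-1.g-1. They differ in one place, and the step between them is a 1.4-fold higher number from compound 1 to compound 2 (0.14 log units; within the scatter). Going by the values given here, compound 2 therefore stands level with compound 1, the only other measured compound, within the scatter.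

Compound 3 (`Cc1cc(CC(=O)N(C)Cc2ccccc2-c2ccc(CN3C[C@@H](C)N[C@@H](C)C3)cc2)on1`) has not yet been measured. It carries 3-methyl-1,2-oxazol-5-yl in place of phenylsulfonyl on a saturated chain carbon bound to a carbonyl carbon.

Among the compounds with values here, only one measured step bears on this change. It concerns the same place on the chain but a different pair of groups, so it is a thin guide. Starting from compound 2 at 6.8 mL.min-1.g-1, and with that single step being a 1.4-fold higher number from compound 1 to compound 2 (0.14 log units; within the scatter), no change beyond the scatter is expected in this assay. The estimated change is a 1.1-fold lower number from compound 2 to compound 3 (0.05 log units; within the scatter). The expected value for compound 3 is 6 mL.min-1.g-1, with an estimated range from 3 mL.min-1.g-1 to 12 mL.min-1.g-1.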

Compound 3, intrinsic clearance in microsomes: 2.4 mL.min-1.g-1
The estimate for compound 3 lay 2.5-fold (0.40 log units) above the measured number, and the stated range ends above it.
By their numbers in this assay, from the lowest: compound 3; then compounds 1 and 2 (each within the scatter of the next).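

In this assay the place on a saturated chain carbon bound to a carbonyl carbon now proves able to shift the number beyond the scatter, which the earlier pair did not show. 3-methyl-1,2-oxazol-5-yl in place of phenylsulfonyl gives a modest step (a 2.8-fold lower number from compound 2 to compound 3 (0.45 log units; beyond the scatter)), and in place of phenoxy it gives another modest step (a 2.0-fold lower number from compound 1 to compound 3 (0.31 log units; beyond the scatter)). Phenoxy and phenylsulfonyl stand within the scatter of each other, whereas the five-membered aromatic ring with 2 hetero atoms sets compound 3 apart from both, at the low end of the three compounds.

The compounds shown leave open whether the methyl of the 3-methyl-1,2-oxazol-5-yl group plays any part in this step, and whether a 1,2-oxazol-5-yl without that methyl, a pyridyl group or a plain benzyl group at the same place would give a similar number in this assay. Nothing given here accounts for the lower number of compound 3, so the reason for this step remains unknown.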